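Isopropyl Added to a Weakly Cytotoxic Amide

The compounds below may be only part of what the source reports. "The series", "measured", "known", "first", "only" and "open" are said of these compounds alone.

Compound 1 `COC(=O)CCCNC(=O)CSC1=C(OC)C(=O)c2ccccc2C1=O` gives 24000 nM in a functional assay on HeLa cells (Homo sapiens) for cytotoxicity, read by MTT assay, with a stated time of 48 h; a lower number here means a stronger inhibitor, a higher number a weaker inhibitor. On these data alone, compound 2 `COC(=O)CNC(=O)CSC1=CC(=O)c2cccc(OC)c2C1=O` shows only a limit, > 100000 nM, in this assay, so its true number is unknown; this is the limit of > 100000 nM in this assay, at which 1 of the 2 values shown sits. Compound 3 `COC(=O)[C@@H](NC(=O)CSC1=CC(=O)c2cccc(OC)c2C1=O)C(C)C` differs from compound 2 by isopropyl in place of hydrogen on a saturated chain carbon bound to an amide-type nitrogen and a carbonyl carbon. Going by the values given here, no measured pair here shows a change of this kind, so the step is expected to be small, in either direction, or none beyond the scatter. Compound 3 is therefore expected near 120000 nM, within 50000 nM to 400000 nM. The expected step is a step that the limit leaves unreadable from compound 2 to compound 3.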

Compound 3, half-maximal inhibitory concentration: > 100000 nM
Compound 3 was reported as a limit; the forecaster's own chance of this, stated with the estimate: 70%; the middle value is on the limit's open side.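

No step can be read from compound 2 to compound 3, because both are reported only as limits: the limit of > 100000 nM in this assay, at which 2 of the 3 values shown sit.

On these data alone, whether isopropyl in place of hydrogen at this chain carbon changes the true value in this assay remains open.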